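The compounds below may be only part of what the source reports. "The series", "measured", "known", "first", "only" and "open" are said of these compounds alone.

Of the compounds shown here, three sharing a dimethyltriazene core have been measured in a functional assay on L1210 cells (Mus musculus) for antiproliferative activity; on this read-out lower numbers stand for lower potency and higher numbers for higher potency (the scale is a negative logarithm). Compound 1 `CN(C)/N=N/c1ccccc1[N+](=O)[O-]` gives 3.28, compound 2 `CN(C)/N=N/c1ccc(C#N)cc1C(N)=O` gives 3.46, and compound 3 `CN(C)/N=N/c1ccccc1C(N)=O` gives 3.31. Compound 3 stands second highest of these three numbers, yet its gaps to the others are small: a number 0.03 log units higher from compound 1 to compound 3 (within the scatter), and a number 0.15 log units lower from compound 2 to compound 3 (within the scatter), both within the scatter. Compound 4 `CN(C)/N=N/c1ccccc1Cl` differs from compound 3 in one place: chloro in place of carbamoyl on an aromatic carbon. Among the compounds with values here, no measured step introduces chloro, so the only guide is how the same aromatic carbon behaved when nitro gave way to carbamoyl, and how the ring responded to losing cyano. Because a number 0.03 log units higher from compound 1 to compound 3 (within the scatter) stayed within the scatter, and because a number 0.15 log units lower from compound 2 to compound 3 (within the scatter) did likewise, a swap at that carbon is expected to shift the number little. Compound 4 is therefore estimated at 3.3, with a range from 3 to 3.6. The expected step is a number 0.01 log units lower from compound 3 to compound 4 (within the scatter), which lies within the scatter.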

Compound 4, logarithm of the reciprocal of the active concentration, log(1/C): 3.26
Beside the measured number, compound 4's estimate is 0.04 log units above it; measured number inside the range.
By their numbers in this assay, from the lowest: compounds 4, 1, 3 and 2 (each within the scatter of the next).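

Chloro in place of carbamoyl gives a number 0.05 log units lower from compound 3 to compound 4 (within the scatter) in this assay and chloro in place of nitro gives a number 0.02 log units lower from compound 1 to compound 4 (within the scatter) on the same aromatic carbon, so carbamoyl, nitro and chloro now all stand within the scatter of one another at this position. Within the data shown here, this is also the first step here that swaps the 3 heavy atoms of carbamoyl, with its 1 hydrogen-bond donor and 1 hydrogen-bond acceptor, for the 1 heavy atom of chloro, with 0 of either, and the read-out does not move beyond the scatter. Nothing measured here explains this tolerance of the position.

On these data alone, whether an amine, a carboxylic acid or a longer chain on this aromatic carbon would also stay within the scatter remains open. As far as these compounds go, it is also open whether chloro would behave the same way with the cyano group of compound 2 on the ring.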